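Working notes on three antiproliferative compounds and a bromo analogue

The source may hold more compounds than are shown below. What is called first, only, known or untested is meant among the compounds shown, and "the series" means these compounds.

Three measured compounds share no common core. Compound 1 `COc1cccc(C(=O)C2OC2c2ccc(F)cc2)c1` gives 17 nM in a functional assay on HepG2 cells (Homo sapiens) for antiproliferative activity, read by sulforhodamine B assay, with a stated time of 48 h; a higher number here means a weaker inhibitor, a lower number a stronger inhibitor. Compound 2 `COc1cc(C2=CC(c3ccc(F)cc3)NC(=S)N2)cc(OC)c1OC` gives 61.9 nM in this assay, and compound 3 `COc1cccc(C2=NNC(c3ccc(Br)cc3)C2O)c1` gives 43 nM. Of the three numbers, that of compound 2 is the highest; its gap to compound 3 lies within the scatter, so no order between these two can be read, while its gap to compound 1 lies beyond the scatter, and compound 1 is the stronger inhibitor of that pair. For the measured compounds named here, no step between two measured compounds that differ in one place is available, so the effect of a single change on this assay has not yet been seen.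

Compound 4 `COc1cc(C2=CC(c3ccc(Br)cc3)NC(=S)N2)cc(OC)c1OC` differs from compound 2 in one place: bromo in place of fluoro on an aromatic carbon. Compound 3 carries a bromophenyl and gives 43 nM; compound 1 carries a fluorophenyl and gives 17 nM; the cores differ, so their two values show nothing about this change alone. The step of a 1.2-fold lower number from compound 2 to compound 4 (0.09 log units; within the scatter) is expected to be small, in no firm direction, and not beyond the scatter. For compound 4 the estimate in this assay is 50 nM, with a range from 20 nM to 150 nM.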

Compound 4, half-maximal inhibitory concentration: 9.5 nM
The estimate for compound 4 lay 5.3-fold (0.72 log units) above the measured number; the measured number lies below the stated range.
By their numbers in this assay, from the lowest: compounds 4 and 1 (each within the scatter of the next); then compounds 3 and 2 (each within the scatter of the next).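

In this assay, for the compounds shown here, the change from 4-fluorophenyl to 4-bromophenyl gives a 6.5-fold lower number from compound 2 to compound 4 (0.81 log units; beyond the scatter) with the rest of the structure unchanged, the first single-place step. This position, on an aromatic carbon of a six-membered aromatic ring of carbon only and para to a large group, is therefore sensitive to which halogen it carries, at least on this shared core, something compound 1 and compound 3 could not show since their cores differ from this one and from each other. Nothing measured here bears on what lies behind the step, which remains an observation on this single pair.

Going by these compounds, two questions stay open: whether chloro, an amine or a carboxylic acid at the same position would give a number in line with the bromo or the fluoro compound, and whether a step of this size would recur on the core of compound 1 or the core of compound 3. Going by these compounds alone, with only one pair in hand, neither a trend across substituents nor a transfer between cores can be drawn from these compounds.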